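The source may report more compounds than this note shows. Statements on the series, on what has been measured and on what is new or still open speak of the compounds shown alone.

Compounds measured so far:
Compound 1, `COc1cc(N(C)CCN(C)C)c(NC(=O)C(Cl)=C(Cl)Cl)cc1Nc1nccc(-c2cn(C)c3ccccc23)n1`; in a functional assay on A549 cells (Homo sapiens) for antiproliferative activity, read by MTT assay, with a stated time of 72 h (on this read-out higher numbers stand for weaker inhibition and lower numbers for stronger inhibition), compound 1 gives only a limit, > 50000 nM.
Compound 2, `COc1cc(N(C)CCN(C)C)c(NC(=O)/C=C\C(C)C)cc1Nc1nccc(-c2cn(C)c3ccccc23)n1`; in this assay compound 2 gives 612 nM.

Within the data shown here, compound 2 therefore stands as the only compound with a true number in this assay; the other value is a limit, (the limit of > 50000 nM in this assay, at which 1 of the 2 values shown sits). Among the measured compounds shown here, the one measured step, an at least 81-fold lower number from compound 1 to compound 2 (1.91 log units; beyond the scatter), replaces the acyl group on the amide carbonyl and leaves the rest of the shared core untouched.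

Compound 3, `COc1cc(N(C)CCN(C)C)c(NC(=O)/C=C\C(C)C)cc1Nc1nccc(-c2cn(C)c3ccc(F)cc23)n1`, differs from compound 2 at a different place: fluoro in place of hydrogen on an aromatic carbon. The acyl group that moved the number so strongly between compound 1 and compound 2 is kept unchanged here, so the measured step does not bear directly on the change from compound 2 to compound 3. A single fluorine added to the aromatic ring of the indole, with no change in donors, acceptors or charge, is expected to give a step in this assay of a 1.2-fold lower number from compound 2 to compound 3 (0.09 log units; within the scatter), that is, none beyond the scatter. Compound 3 is accordingly estimated at 500 nM, with a range from 200 nM to 1500 nM.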

Compound 3, half-maximal inhibitory concentration: 6140 nM
Beside the measured number, compound 3's estimate is 12-fold (1.09 log units) below it; the measured number lies above the stated range.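

Up to this point, only the acyl group on the carbonyl had been seen to move the number, and the aromatic part of the molecule had not been tested. In this assay, the change from 1-methyl-1H-indol-3-yl to 5-fluoro-1-methyl-1H-indol-3-yl, with that acyl group held constant, gives a 10-fold higher number from compound 2 to compound 3 (1.00 log units; beyond the scatter), so this aromatic carbon is also a place where the read-out responds, and in the direction of weaker inhibition, even though the entering fluoro adds only one heavy atom, with no hydrogen-bond donors, no hydrogen-bond acceptors and no net charge. Nothing given here bears on why this single replacement has an effect of this size.

What the compounds shown leave open is whether chloro, methoxy or a nitrile on this same aromatic carbon would raise the number as fluoro does, or whether the effect belongs to fluoro alone. Also open, on these data alone, is whether the step would hold with an acyl group other than 3-methylbut-1-en-1-yl, such as a plain ethenyl, since it rests on a single pair of compounds.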